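Series notes: benzylsulfanyl swap on the triazolopyrimidine core

This account rests on a few compounds, and the source may have more. Where it says the series, first, only, none or still open, it means among the compounds named here.

Measured so far, in a functional assay on BGC-823 cells (Homo sapiens) for inhibition, read by MTT assay, with a stated time of 72 h; on this read-out higher numbers stand for weaker inhibition and lower numbers for stronger inhibition:
- Compound 1, `Cc1cc(N2CC[C@@H](C)[C@@H](N(C)c3ncnc4[nH]ccc34)C2)n2ncnc2n1`: compound 1 gives 67400 nM
- Compound 2, `Cc1cc(N2CC[C@@H](C)[C@@H](N(C)c3ncnc4[nH]ccc34)C2)n2nc(SCc3ccc(F)c(Cl)c3)nc2n1`: compound 2 gives 98900 nM

Among the measured compounds shown here, compound 2 stands at the highest of the two numbers so far, with compound 1 its only neighbour; the single measured step, a 1.5-fold higher number from compound 1 to compound 2 (0.17 log units; within the scatter), is within the scatter, so the two compounds cannot be ordered against each other on this evidence.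

Compound 3, `COc1ccc(CSc2nc3nc(C)cc(N4CC[C@@H](C)[C@@H](N(C)c5ncnc6[nH]ccc56)C4)n3n2)cc1`, is not yet measured. It differs from compound 2 in one place: 4-methoxyphenyl in place of 3-chloro-4-fluorophenyl on a saturated chain carbon bound to a sulfur

For the measured compounds named here, no measured step bears directly on this change. Going by the values given here, the one step known, a 1.5-fold higher number from compound 1 to compound 2 (0.17 log units; within the scatter), concerns the presence or absence of the whole (3-chloro-4-fluorobenzyl)sulfanyl group, not the identity of its aromatic substituents, and it was itself within the scatter. With nothing in the data to move the number in either direction, the working expectation is a step of a 1.1-fold lower number from compound 2 to compound 3 (0.04 log units; within the scatter), that is, none beyond the scatter. Compound 3 is therefore estimated at 90000 nM in this assay, with a range from 35000 nM to 250000 nM.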

Compound 3, half-maximal inhibitory concentration: 69900 nM
Compound 3: the middle estimate sits 1.3-fold (0.11 log units) above what was measured; the measured number falls inside the stated range.
By their numbers in this assay, from the lowest: compounds 1, 3 and 2 (each within the scatter of the next).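

Changing the aromatic group at this place, 4-methoxyphenyl in place of 3-chloro-4-fluorophenyl on a saturated chain carbon bound to a sulfur, gives in this assay a 1.4-fold lower number from compound 2 to compound 3 (0.15 log units; within the scatter), so exchanging the chlorine and fluorine substituents for a methoxy group cannot be told apart from repeat-measurement noise on this read-out. Among the compounds shown here, the second benzyl-type group also fails to separate from the parent: (4-methoxybenzyl)sulfanyl in place of hydrogen on an aromatic carbon gives a 1.0-fold higher number from compound 1 to compound 3 (0.02 log units; within the scatter), so two differently substituted groups at this position now both sit within the scatter of the unsubstituted hydrogen, where previously only one such group had been seen. No measurement is available that would explain this flat picture.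

On these data alone, it remains open whether a group of another kind on the benzyl ring, such as an amine or a carboxylic acid, or a longer chain in place of the benzyl group, would shift the number beyond the scatter in this assay. The compounds shown also leave open whether this position behaves the same way when other parts of the shared core are changed.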